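The source may report more compounds than this note shows. Statements on the series, on what has been measured and on what is new or still open speak of the compounds shown alone.

Measured compounds in a functional assay on HT-29 cells (Homo sapiens) for cytotoxicity, read by sulforhodamine B assay; a lower number here means a stronger inhibitor, a higher number a weaker inhibitor:
compound 1 `C=C1[C@@H](OC(C)=O)C[C@@H]2[C@](C)(COC=O)[C@H](OC(C)=O)CC[C@@]2(C)[C@@H]1C[C@@H](Nc1ccccc1C(=O)O)C1=CCOC1=O` gives 28700 nM
compound 2 `C=C1[C@@H](OC(C)=O)C[C@@H]2[C@](C)(CO[Si](C)(C)C(C)(C)C)[C@H](OC(C)=O)CC[C@@]2(C)[C@@H]1C[C@@H](Nc1cccc(F)c1)C1=CCOC1=O` gives 4520 nM
compound 3 `C=C1[C@@H](OC(C)=O)C[C@@H]2[C@](C)(COC=O)[C@H](OC(C)=O)CC[C@@]2(C)[C@@H]1C[C@@H](Nc1cccc2ccccc12)C1=CCOC1=O` gives 8670 nM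

Among these three, compound 3 stands second highest in this assay. Its nearest neighbour is compound 2, whose value is within the scatter of that of compound 3, so no order can be read between them. Within the data shown here, compound 1 lies furthest away, and the one step recorded between measured compounds, a 3.3-fold lower number from compound 1 to compound 3 (0.52 log units; beyond the scatter), is a modest change beyond the scatter.

Compound 4 `C=C1[C@@H](OC(C)=O)C[C@@H]2[C@](C)(COC=O)[C@H](OC(C)=O)CC[C@@]2(C)[C@@H]1C[C@@H](Nc1cccc(F)c1)C1=CCOC1=O` is not yet measured. It differs from compound 3 in one place: 3-fluorophenyl in place of naphthalen-1-yl on an amine nitrogen. Among the measured compounds shown here, no recorded step matches this change, so the step from compound 1 to compound 3 bears on it only in showing that swapping the group on the amine nitrogen can shift the number by a modest amount. Compound 2 carries the same 3-fluorophenyl group as compound 4 but a different group elsewhere on the core, and its value sits within the scatter of that of compound 3. On that basis the step of a 1.3-fold lower number from compound 3 to compound 4 (0.13 log units; within the scatter) is expected to stay within the scatter, with no clear direction. Compound 4 is therefore estimated at 6500 nM in this assay, with a range from 2500 nM to 16000 nM.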

Compound 4, half-maximal inhibitory concentration: 9410 nM
The estimate for compound 4 lay 1.4-fold (0.16 log units) below the measured number, and the stated range covers the measured number.
By their numbers in this assay, from the lowest: compounds 2, 3 and 4 (each within the scatter of the next, the first and the last beyond it); then compound 1.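

In this assay, the change on the amine nitrogen from naphthalen-1-yl to 3-fluorophenyl gives no readable order: the step is a 1.1-fold higher number from compound 3 to compound 4 (0.04 log units; within the scatter), so on this core these two groups cannot be told apart, despite the loss of one aromatic ring. The step of a 3.0-fold lower number from compound 1 to compound 4 (0.48 log units; beyond the scatter) now joins the earlier one from the same compound, so compound 1, with its 2-carboxyphenyl group, has the highest number of the three compounds that share the rest of the structure, and by a modest margin. Among these compounds, with 3-fluorophenyl held fixed, the result also gives the first reading at a second place: putting a group of 2 heavy atoms in place of a group of 7 heavy atoms, on an oxygen on a saturated carbon, gives a 2.1-fold higher number from compound 2 to compound 4 (0.32 log units; beyond the scatter), a modest step just beyond the scatter.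

Still open, going by these compounds, is how a plain phenyl group on the amine nitrogen, or a methyl ester in place of the carboxylic acid of 2-carboxyphenyl, would read on this core. No supporting data are available to explain any of these shifts.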